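Swapping a Dichlorophenyl for a Cyclohexenylmethyl Group

This account rests on a few compounds, and the source may have more. Where it says the series, first, only, none or still open, it means among the compounds named here.

Measured so far in a functional assay on T47D cells (Homo sapiens) for cytotoxicity, read by sulforhodamine B assay, with a stated time of 72 h; on this read-out lower numbers stand for stronger inhibition and higher numbers for weaker inhibition:
- compound 1 `Cc1ccc(S(=O)(=O)n2cnc3c(NCc4ccc(F)cc4F)ncnc32)cc1` gives 116000 nM
- compound 2 `Cc1ccc(S(=O)(=O)n2cnc3c(NCc4ccc(Cl)cc4Cl)ncnc32)cc1` gives 47600 nM

Among these two numbers, compound 2 stands at the lower end, and the only measured step is a 2.4-fold lower number from compound 1 to compound 2 (0.39 log units; beyond the scatter), which swaps fluorine for chlorine on an otherwise unchanged aromatic ring.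

Compound 3 `Cc1ccc(S(=O)(=O)n2cnc3c(NCCC4C=CCCC4)ncnc32)cc1` keeps the shared core and differs from compound 2 in one place: (cyclohex-2-en-1-yl)methyl in place of 2,4-dichlorophenyl on a saturated chain carbon bound to a nitrogen on an aromatic ring. This is a more radical change than the halogen swap. The aromatic ring with its two chlorines is removed altogether and a non-aromatic ring with one double bond takes its place. Among the measured compounds shown here, no measured step compares an aromatic with a non-aromatic ring here, so the measured data give no direct guide to the size or direction of this step in this assay.

Without such a guide, the number for compound 3 is expected to lie in the same weak region as the two measured compounds, and the step of a 1.7-fold higher number from compound 2 to compound 3 (0.23 log units; within the scatter) is estimated to be small. Compound 3 is therefore estimated at 80000 nM, within a range from 25000 nM to 250000 nM.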

Compound 3, half-maximal inhibitory concentration: 34500 nM
Beside the measured number, compound 3's estimate is 2.3-fold (0.37 log units) above it; the range from low to high includes it.
By their numbers in this assay, from the lowest: compounds 3 and 2 (each within the scatter of the next); then compound 1.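

In this assay the change from the 2,4-dichlorophenyl group to the (cyclohex-2-en-1-yl)methyl group gives a 1.4-fold lower number from compound 2 to compound 3 (0.14 log units; within the scatter), so at this place, on a saturated chain carbon bound to a nitrogen on an aromatic ring, removing the aromatic ring and both chlorines leaves the number within the scatter of compound 2. The same swap made on the fluorinated compound gives a 3.4-fold lower number from compound 1 to compound 3 (0.53 log units; beyond the scatter), which means that, among these three compounds, neither an aromatic ring nor a halogen is needed to reach the level of compound 2. Nothing measured here explains why two such different groups give numbers this close.

The compounds shown cannot separate the part played by the ring's double bond from that of the ring itself, since a fully saturated cyclohexyl ring, an open hexyl chain and a plain phenyl ring without halogens are absent from this set. They also leave open whether a group of a different kind at this place, such as an amine or a carboxylic acid, would shift the number well beyond the scatter.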